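The source may report more compounds than this note shows. Statements on the series, on what has been measured and on what is new or still open speak of the compounds shown alone.

Series notes. In a functional assay for inhibition of sodium/hydrogen exchanger (Oryctolagus cuniculus) (on this read-out lower numbers stand for stronger inhibition and higher numbers for weaker inhibition), compound 2 `Cc1cc(C2CCC2)c(S(C)(=O)=O)cc1C(=O)N=C(N)N` gives 8.2 nM, the lowest number of the three measured. Compound 1 `CCc1cc(Cl)c(S(C)(=O)=O)cc1C(=O)N=C(N)N` gives 63 nM in this assay, and compound 3 `Cc1cc(-c2cc(C(F)(F)F)cc(C(F)(F)F)c2)c(S(C)(=O)=O)cc1C(=O)N=C(N)N` gives 2800 nM in this assay; both stand beyond the scatter above compound 2, compound 3 by far the most. Compound 4 `Cc1cc(Sc2cccc(Cl)c2)c(S(C)(=O)=O)cc1C(=O)N=C(N)N` has not been measured in this assay. It differs from compound 2 by (3-chlorophenyl)sulfanyl in place of cyclobutyl on an aromatic carbon. Among the measured compounds only compound 3 carries an aromatic ring at that carbon, and a clear weakening is expected for compound 4 because compound 3 gives 2800 nM, though compound 3 carries two trifluoromethyl groups where compound 4 carries one chlorine, so a smaller loss is estimated. The estimated step is an 18-fold higher number from compound 2 to compound 4 (1.26 log units; beyond the scatter). Compound 4 is expected to give 150 nM, within 30 nM to 800 nM.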

Compound 4, half-maximal inhibitory concentration: 37 nM
For compound 4 the middle estimate is 4.1-fold (0.61 log units) above the measured one, and the stated range covers the measured number.
By their numbers in this assay, from the lowest: compound 2; then compounds 4 and 1 (each within the scatter of the next); then compound 3.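

In this assay the aromatic carbon ortho to a methylsulfonyl group takes (3-chlorophenyl)sulfanyl in place of cyclobutyl at only a modest cost (a 4.5-fold higher number from compound 2 to compound 4 (0.65 log units; beyond the scatter)). An aromatic ring at this carbon therefore does not by itself bring a number as high as that of compound 3, with compound 4 at 37 nM against compound 3 at 2800 nM in the same assay. No measurement at hand accounts for the step.

From the compounds shown here alone, whether the sulfur link or the chlorine separates compound 4 from compound 3 remains open. Also open, going by these compounds, is how an amine or a phenoxy group would fare at this carbon.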